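Notes on compound 4: amide in place of urea

The source may hold more compounds than are shown below. What is called first, only, known or untested is meant among the compounds shown, and "the series" means these compounds.

Three compounds of the shared core have numbers in a functional assay on OVCAR-5 cells (Homo sapiens) for inhibition, read by sulforhodamine B assay, with a stated time of 48 h, tested at 1 uM; on this read-out higher numbers stand for a weaker effect at the one concentration tested and lower numbers for a stronger effect. Compound 1 `O=C(Nc1cccc(-n2cc(-c3ccncc3)c(-c3cc(O)cc(Cl)c3)n2)c1)Nc1ccc(Cl)c(Cl)c1` gives 56%. Compound 2 `COc1cc(Cl)cc(-c2nn(-c3cccc(NC(=O)Nc4cc(C(F)(F)F)cc(C(F)(F)F)c4)c3)cc2-c2ccncc2)c1` gives 59%. Compound 3 `COc1cc(Cl)cc(-c2nn(-c3cccc(NC(=O)Nc4ccc(Cl)c(Cl)c4)c3)cc2-c2ccncc2)c1` gives 87%, the highest of the three numbers and thus the weakest effect at the one concentration; the nearest is compound 2 and the furthest compound 1. For the measured compounds named here, the only single-place step known, a number 31 percentage points higher from compound 1 to compound 3 (beyond the scatter), concerns the substituent on the oxygen and not the carbonyl end of the molecule. Compound 4 `COc1cc(Cl)cc(-c2nn(-c3cccc(NC(=O)c4cccc(C(F)(F)F)c4)c3)cc2-c2ccncc2)c1` is not yet measured; it differs from compound 3 in 3-(trifluoromethyl)phenyl in place of (3,4-dichlorophenyl)amino on a carbonyl carbon. Going by the values given here, compound 2 and compound 3 differ at that same end but in more than one place, so their two numbers show only that the trifluoromethyl-bearing ring went with the lower number. Among the compounds with values here, no measured step bears directly on the change from compound 3 to compound 4, so only a rough expectation is possible: the number of compound 4 is expected to move downward by a number 17 percentage points lower from compound 3 to compound 4 (beyond the scatter), a step that may prove no larger than scatter. Compound 4 is estimated at 70%, within a range from 45% to 92%.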

Compound 4, a percentage reported as activity, at one concentration (the size of the read-out at that concentration, not a potency): 96%
Compound 4: middle estimate off by 26 percentage points, on the low side; measured number above the stated range.
By their numbers in this assay, from the lowest: compounds 1 and 2 (each within the scatter of the next); then compounds 3 and 4 (each within the scatter of the next).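

In this assay, for the compounds shown here, the first step at the carbonyl end reads a number 9 percentage points higher from compound 3 to compound 4 (within the scatter), so 3-(trifluoromethyl)phenyl in place of (3,4-dichlorophenyl)amino on this carbonyl carbon gives no separation between the two compounds. This change also removes the hydrogen-bond donor counted on the group that leaves, and with the methyl on oxygen kept, the read-out does not register that loss beyond the scatter. No available evidence bears on this result.

On these data alone, whether the same change would also fall within the scatter with hydrogen in place of that methyl on oxygen, as in compound 1, remains open. Also open, as far as these compounds go, is how a group such as a piperazine or a carboxylic acid on the carbonyl carbon would read in this assay.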